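This account rests on a few compounds, and the source may have more. Where it says the series, first, only, none or still open, it means among the compounds named here.

Compound 1, `COc1cccc(-c2cnc(NC(=O)c3ccc(F)cc3)n2C)c1`, was examined in a toxicity assay on THP-1 cells (Homo sapiens) for inhibition; on this read-out lower numbers stand for higher toxicity in this test and higher numbers for lower toxicity in this test. There compound 1 gives only a limit, > 100000 nM, and no number. Two close relatives were measured the same way. Compound 2, `Cn1c(-c2cccc([N+](=O)[O-])c2)cnc1NC(=O)c1ccc(F)cc1`, also stops at a limit, giving > 50000 nM. Compound 3, `COc1cccc(-c2cnc(NC(=O)c3ncc[nH]3)n2C)c1`, likewise gives only a limit, > 100000 nM. Every value sits at a limit, so the two changes already tried cannot be sized: a step that the two limits leave unreadable from compound 1 to compound 2 and a step that the two limits leave unreadable from compound 1 to compound 3. Compound 1 therefore stands among three compounds that all show low toxicity in this assay, two of them at the limit of > 100000 nM in this assay, at which 2 of the 3 values shown sit, and one at the limit of > 50000 nM in this assay, at which 1 of the 3 values shown sits.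

The next compound, compound 4, `Cn1c(-c2ccccc2Br)cnc1NC(=O)c1ccc(F)cc1`, differs from compound 1 in one place: 2-bromophenyl in place of 3-methoxyphenyl on an aromatic carbon. Both measured steps change a single group on the same core without leaving the limit, and neither is readable, so they give no direction for this new change. Compound 4 is expected to behave like compound 1. The expected step, a number no higher from compound 1 to compound 4 (the limit leaves the size open), should stay within the scatter. The estimate for compound 4 in this assay is 100000 nM, expected to lie between 30000 nM and 300000 nM, and most likely to be reported once more only as a limit.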

Compound 4, half-maximal cytotoxic concentration: > 100000 nM
Compound 4: a limit, no number; the forecaster's own chance of this, stated with the estimate: 75%; the middle value sits exactly at the limit.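

In this assay compound 4 gives only a limit, > 100000 nM, and no number. Compound 1 also stops at a limit, so the change from compound 1 to compound 4 cannot be read. The compounds shown leave open how large any of these single changes is and at what concentration any of the four compounds becomes toxic to the cells.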